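The source may hold more compounds than are shown below. What is called first, only, known or untested is meant among the compounds shown, and "the series" means these compounds.

Measured in a functional assay on A-375 cells (Homo sapiens) for cytotoxicity, read by CCK-8 assay, with a stated time of 24 h; a higher number here means a weaker inhibitor, a lower number a stronger inhibitor:
- Compound 1 `COc1ccccc1Oc1c(N)nc(-c2cccc(C)c2)nc1OCCO`: 1380 nM
- Compound 2 `COc1ccccc1Oc1c(N)nc(-c2cccc(F)c2)nc1OCCO`: 8530 nM

Compound 2 holds the higher of the two numbers, 8530 nM, which makes it the weaker inhibitor of the pair in this assay. Compound 3 `COc1ccccc1Oc1c(N)nc(-c2cccc(I)c2)nc1OCCO` carries one change from compound 2: iodo in place of fluoro on an aromatic carbon. Within the data shown here, no measured step makes this exchange directly. Among the measured compounds shown here, the only guide is the modest step of a 6.2-fold higher number from compound 1 to compound 2 (0.79 log units; beyond the scatter), which put fluoro in place of methyl on that same aromatic carbon and lies beyond the scatter. It shows that the fluoro compound 2 stands above its methyl partner, but one step cannot settle where iodo falls. A step toward a lower number, no larger than that one, is therefore expected. The estimated change is a 2.8-fold lower number from compound 2 to compound 3 (0.45 log units; beyond the scatter). For compound 3 the expected value is 3000 nM, with an estimated range of 900 nM to 9000 nM.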

Compound 3, half-maximal inhibitory concentration: 1230 nM
Estimate against measurement, compound 3: 2.4-fold (0.39 log units) above; the range from low to high includes it.
By their numbers in this assay, from the lowest: compounds 3 and 1 (each within the scatter of the next); then compound 2.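

In this assay the step from fluoro to iodo on this aromatic carbon is (a 6.9-fold lower number from compound 2 to compound 3 (0.84 log units; beyond the scatter)), so the higher number of compound 2 does not extend to every halogen at this position. Iodo and methyl cannot be told apart here (a 1.1-fold lower number from compound 1 to compound 3 (0.05 log units; within the scatter)), which leaves compound 2 as the only one of the three that stands apart, with both of its steps beyond the scatter. No measurement shown here explains why fluoro differs from iodo and methyl at this position.

The compounds shown leave open how chloro or bromo would read on this carbon, and so whether the numbers follow any order across the halogens. They also leave open how an amine or a carboxylic acid would read there, and whether the same differences hold on any other core.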